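One group exchanged in compound 1

The compounds below may be only part of what the source reports. "The series", "measured", "known", "first", "only" and "open" are said of these compounds alone.

Values measured so far in a physicochemical assay for lipophilicity, read by HPLC, at pH 7.5; a higher number here means a more lipophilic compound, a lower number a more polar compound:
Compound 1 `CC[C@@H](Nc1c(C#N)c(-c2ccc(-c3cccc(C)c3F)cc2)nc2cnccc12)C(N)=O` gives 3
Compound 2 `CC[C@H](Nc1c(C#N)c(-c2ccc(Br)cc2)nc2cnccc12)C(N)=O` gives 2.3
Compound 3 `CCOc1ccccc1-c1ccc(-c2nc3cnccc3c(N[C@H](CC)C(=O)N(C)C)c2C#N)cc1` gives 3.7

In this assay compound 1 stands second highest of the three, with compound 2 lower and compound 3 higher, and both gaps lie beyond the usual scatter. Compound 4 `CC[C@@H](Nc1c(C#N)c(-c2ccc(-c3cccc(CO)c3)cc2)nc2cnccc12)C(N)=O` has not been measured yet. It carries 3-(hydroxymethyl)phenyl in place of 2-fluoro-3-methylphenyl on an aromatic carbon. Going by the values given here, no two measured compounds differ in one place only, so the expectation rests on this structural change alone. In this assay a downward step beyond the scatter is expected (a number 0.80 log units lower from compound 1 to compound 4 (beyond the scatter)). Compound 4 is estimated at 2.2 (expected range 1.8 to 2.6).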

Compound 4, distribution coefficient: 2
For compound 4 the middle estimate is 0.20 log units above the measured one, and the stated range covers the measured number.
By their numbers in this assay, from the lowest: compounds 4 and 2 (each within the scatter of the next); then compound 1; then compound 3.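

Going by these compounds alone, this is the first step that isolates a single change at this position, on an aromatic carbon para to a large group. In this assay, exchanging 2-fluoro-3-methylphenyl for 3-(hydroxymethyl)phenyl gives a number 1.00 log units lower from compound 1 to compound 4 (beyond the scatter), although both groups have the same number of heavy atoms and the entering group adds a hydrogen-bond donor and acceptor. Nothing available explains the size of this step.

Because the fluorine, methyl and hydroxymethyl groups all differ in one exchange, their separate contributions remain unresolved. Going by these compounds, how an aminomethyl group or a carboxylic acid at this position would read in this assay also remains open.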